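The compounds below may be only part of what the source reports. "The series", "measured", "known", "first", "only" and "open" are said of these compounds alone.

Measured so far in this study:

Compound 1, `CCCCCCC(C)C(=O)NCC(C)(C)CC1=C(O)C(=O)c2ccccc2C1=O`, gives 15500 nM in an ADME assay on Vero cells (Chlorocebus sabaeus) for cytotoxicity, read by reporter gene assay, with a stated time of 4 days; a higher number here means a weaker inhibitor, a lower number a stronger inhibitor.
Compound 2, `CCCCCCCCC(=O)NCC(C)(C)CC1=C(O)C(=O)c2ccccc2C1=O`, gives 16700 nM in this assay.
Compound 3, `CCCCCCC(C)C(=O)OCC(C)(C)CC1=C(O)C(=O)c2ccccc2C1=O`, gives 450 nM in this assay.

Compound 1 and compound 2 share a core and differ only by octyl in place of 1-methylheptyl on a carbonyl carbon. The step of a 1.1-fold higher number from compound 1 to compound 2 (0.03 log units; within the scatter) shows that this swap left the cytotoxicity reading essentially where it was. Compound 3 carries a different core; the difference between the core of compound 1 and the core of compound 3 is not broken down here. In this assay compound 3 stands well apart from both, with compound 1 and compound 2 giving far higher numbers.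

Compound 4, `CCCCCCCCC(=O)OCC(C)(C)CC1=C(O)C(=O)c2ccccc2C1=O`, has not yet been measured. It differs from compound 3 by octyl in place of 1-methylheptyl on a carbonyl carbon. This is the same kind of change that turns compound 1 into compound 2, but not the same: in compound 1 the place is a carbonyl carbon whose other neighbour is an amide-type nitrogen, while in compound 3 it is a carbonyl carbon whose other neighbour is oxygen next to a carbonyl group. Within the data shown here, the one measured example of this swap moved the number only within the scatter, so the step from compound 3 to compound 4 is expected to be of similar size, a 1.1-fold higher number from compound 3 to compound 4 (0.05 log units; within the scatter), resting on the step of a 1.1-fold higher number from compound 1 to compound 2 (0.03 log units; within the scatter) and on the value of compound 3, 450 nM. On that basis compound 4 is estimated at 500 nM, most likely between 200 nM and 1300 nM.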

Compound 4, half-maximal inhibitory concentration: 150000 nM
Compound 4: middle estimate off by 300-fold (2.48 log units), on the low side; measured number above the stated range.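

Putting octyl in place of 1-methylheptyl on the carbonyl carbon gives a 330-fold higher number from compound 3 to compound 4 (2.52 log units; beyond the scatter) in this assay, so on the core of compound 3 this small rearrangement of the same atoms changes the reading a great deal. The same swap had almost no effect on the core of compound 1, and the two results clearly disagree, so a step measured on one core in this series cannot simply be carried to the other: the same change on two cores in this assay, a 1.1-fold higher number (0.03 log units; within the scatter) from compound 1 to compound 2 and a 330-fold higher number (2.52 log units; beyond the scatter) from compound 3 to compound 4, 310-fold (2.49 log units) apart, beyond the scatter of two such steps

With a single pair on each core, this shows that the result of the swap depended on the core in these four compounds, but it does not show why, and it cannot predict what the swap would do on any further core.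

The compounds shown leave open whether the large step on the core of compound 3 is specific to octyl and 1-methylheptyl, or whether a longer chain such as decyl, or a shorter one such as hexyl, would fall near compound 3 or near compound 4. They also leave open how a chain ending in a carboxylic acid or an amine would read on either core.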